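A few compounds are considered here, and "the series" means these few. Any claim that something is new, unique, unknown or untested is made for them only; others in the source may bear on it.

Measured so far:
compound 1 `Oc1cccc(-c2cc(-c3ccccc3)cc(-c3cccs3)n2)c1`: 51.2%
compound 2 `Oc1cccc(-c2cc(-c3ccccc3)nc(-c3ccccc3)c2)c1`: 11.5%

Both numbers come from an assay on isolated protein for inhibition of DNA topoisomerase 1 (Homo sapiens), with a stated time of 30 min, tested at 100 uM; a lower number here means a weaker effect, a higher number a stronger effect of the compound at the concentration tested. Compound 2 stands lowest of the two; compound 1 lies higher, a gap beyond the scatter. Compound 3 `Oc1cccc(-c2cc(-c3ccccc3)nc(-c3ccncc3)c2)c1` differs from compound 2 in one place: pyridin-4-yl in place of phenyl on an aromatic carbon. Going by the values given here, no step between measured compounds covers a change of this kind, so no size can be read from the series itself. The step from compound 2 to compound 3 in this assay is expected to be small, likely within the scatter, in either direction. Compound 3 is estimated at 15%, expected between 0% and 40%. This estimate means an expected step of a number 3.5 percentage points higher from compound 2 to compound 3 (within the scatter).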

Compound 3, a percentage reported as inhibition, at one concentration (the size of the read-out at that concentration, not a potency): 60.8%
Beside the measured number, compound 3's estimate is 45.8 percentage points below it, outside the stated range (above it).
By their numbers in this assay, from the lowest: compound 2; then compounds 1 and 3 (each within the scatter of the next).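

On the aromatic carbon next to the ring nitrogen, pyridin-4-yl in place of phenyl gives a number 49.3 percentage points higher from compound 2 to compound 3 (beyond the scatter) in this assay, so this position responds strongly to a single ring atom. Going by these compounds alone, the two groups have the same heavy-atom count and differ in one ring nitrogen and one hydrogen-bond acceptor, which the earlier compounds did not isolate. No evidence at hand accounts for the size of this step. Still open, from the compounds shown here alone, is whether pyridin-3-yl or pyridin-2-yl at this position would give a similar read-out, and whether a phenyl carrying an amine or a carboxylic acid would do so.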